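The source may hold more compounds than are shown below. What is called first, only, known or untested is meant among the compounds shown, and "the series" means these compounds.

Compound 1: `C[C@@H]1C[C@H]2C(=O)C(C)(C)[C@H](O)CC[C@]2(O)[C@@]1(C)CCC1=CC(=O)OC1`, > 10000 nM. Compound 2: `C[C@@H]1CC[C@@]2(O)[C@@H](C[C@@H](O)C2(C)C)C(=O)[C@@]1(C)CCC1=CC(=O)OC1`, > 10000 nM.

Compound 1, `C[C@@H]1C[C@H]2C(=O)C(C)(C)[C@H](O)CC[C@]2(O)[C@@]1(C)CCC1=CC(=O)OC1`, was tested in a functional assay on A549 cells (Homo sapiens) for cytotoxicity, read by MTT assay, with a stated time of 3 days; a higher number here means a weaker inhibitor, a lower number a stronger inhibitor. In this assay compound 1 gives > 10000 nM, which is a limit of the assay rather than a number. Compound 2, `C[C@@H]1CC[C@@]2(O)[C@@H](C[C@@H](O)C2(C)C)C(=O)[C@@]1(C)CCC1=CC(=O)OC1`, stands in the same place: in this assay compound 2 gives > 10000 nM, again a limit and not a number. Among the measured compounds shown here, both values shown sit at the limit of > 10000 nM in this assay, at which 2 of the 2 values shown sit, so nothing on these numbers separates compound 1 from compound 2, and no step between measured compounds can be drawn.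

Compound 3, `C[C@@H]1CC[C@]2(O)[C@H](C[C@@H](O)C2(C)C)C(=O)[C@@]1(C)CCC1=CC(=O)OC1`, has not yet been measured. Its difference from compound 2 is the two compounds have the same atoms and bonds and differ only in configuration as drawn: 2 of 5 stereo elements differ; a stereocentre at a saturated ring carbon is drawn R in compound 2 and S in compound 3; a stereocentre at a saturated ring carbon is drawn R in compound 2 and S in compound 3. Given that both measured compounds sit at the limit and the two compounds have the same atoms and bonds, no change beyond the scatter is expected in this assay, the expected step being a step that the limit leaves unreadable from compound 2 to compound 3. Compound 3 is therefore estimated at 20000 nM, most likely reported once more as a limit, within 8000 nM to 60000 nM.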

Compound 3, half-maximal inhibitory concentration: > 10000 nM
Compound 3 gave a limit, no number; the forecaster's own chance of this, stated with the estimate: 80%; the middle value is on the limit's open side.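

In this assay compound 3 gives > 10000 nM, a limit and not a number. Among the compounds shown here, compound 2 also sits at a limit, so no step from compound 2 to compound 3 can be read. The compounds shown leave open whether configuration has any effect in this assay, as none of them gives a number.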